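The source may report more compounds than this note shows. Statements on the series, on what has been measured and on what is new or still open speak of the compounds shown alone.

Measured so far in a functional assay on K562 cells (Homo sapiens) for antiproliferative activity, read by MTT assay, with a stated time of 24 h; a lower number here means a stronger inhibitor, a higher number a weaker inhibitor:
- compound 1 `COC(=O)c1scc(-c2ccc(NC(=O)c3ccccn3)cc2)c1OC` gives 24200 nM
- compound 2 `COC(=O)c1scc(-c2ccc(NC(=O)c3ccc(F)c(Cl)n3)cc2)c1OC` gives 8250 nM

Compound 2 has the lower of these two numbers, which makes it the stronger inhibitor of the pair. The next compound is compound 3 `COC(=O)c1scc(-c2ccc(NC(=O)c3cc(I)ccc3F)cc2)c1OC`, and its change is 2-fluoro-5-iodophenyl in place of 6-chloro-5-fluoropyridin-2-yl on a carbonyl carbon. For the measured compounds named here, only one measured step bears on this. That step, a 2.9-fold lower number from compound 1 to compound 2 (0.47 log units; beyond the scatter), changed the same group on the carbonyl carbon and was modest. Going by the values given here, no measured compound carries a ring of carbon only there, so the data give no clear direction. A step no larger than that modest one is expected, in either direction. The estimate is a 1.2-fold lower number from compound 2 to compound 3 (0.07 log units; within the scatter), so no shift beyond the scatter is expected. Compound 3 is expected at about 7000 nM, with a likely range from 2500 nM to 20000 nM in this estimate.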

Compound 3, half-maximal inhibitory concentration: 35600 nM
For compound 3 the middle estimate is 5.1-fold (0.71 log units) below the measured one; measured number outside the range, above it.
By their numbers in this assay, from the lowest: compound 2; then compounds 1 and 3 (each within the scatter of the next).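

In this assay, the group on the carbonyl carbon can now be seen to move the number in either direction: a 4.3-fold higher number from compound 2 to compound 3 (0.63 log units; beyond the scatter), so carrying halogens on the ring does not by itself give a lower number here. Set against the pyridin-2-yl group of compound 1, the 2-fluoro-5-iodophenyl group gives a 1.5-fold higher number from compound 1 to compound 3 (0.17 log units; within the scatter), which means that this carbon-only ring with fluorine and iodine shows no separation from that simpler ring. Nothing available explains the gap between compound 2 and compound 3.

As far as these compounds go, compound 2 and compound 3 differ in both the ring nitrogen and the halogens, so the share of each in that gap stays open. Also open, from the compounds shown here alone, is how an amine or a carboxylic acid on this ring would behave.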